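Hydroxyl for Amine on a Six-Membered Ring

The source may hold more compounds than are shown below. What is called first, only, known or untested is meant among the compounds shown, and "the series" means these compounds.

Compound 3 `COc1cc[nH]c1/C=C1\C(=O)Nc2ccc([N+](=O)[O-])c(N3CCC(N)CC3)c21` is one of three measured compounds built on a shared core that carries a nitro group. In a functional assay on RKO cells (Homo sapiens) for antiproliferative activity, read by MTT assay, with a stated time of 5 days (on this read-out higher numbers stand for weaker inhibition and lower numbers for stronger inhibition), compound 3 gives < 10 nM, which is a limit of the assay rather than a number (the limit of < 10 nM in this assay, at which 1 of the 3 values shown sits). Compound 2 `COc1cc[nH]c1/C=C1\C(=O)Nc2ccc([N+](=O)[O-])c(N[C@H]3CC[C@H](N)C3)c21` also reaches only a limit, < 15 nM (the limit of < 15 nM in this assay, at which 1 of the 3 values shown sits). Compound 1 `COc1cc[nH]c1/C=C1\C(=O)Nc2ccc([N+](=O)[O-])c(N3CC[C@@H](O)C3)c21` gives 32 nM in this assay. Compound 4 `COc1cc[nH]c1/C=C1\C(=O)Nc2ccc([N+](=O)[O-])c(N3CCCC(O)C3)c21` differs from compound 3 by 3-hydroxypiperidin-1-yl in place of 4-aminopiperidin-1-yl on an aromatic carbon. The step that bears on this change is an at least 3.2-fold lower number from compound 1 to compound 3 (0.50 log units; beyond the scatter), in which an amine-bearing ring replaced a hydroxyl-bearing one; compound 4 reverses that exchange on a six-membered ring. Compound 4 is therefore expected to show a higher number, an at least 3.0-fold higher number from compound 3 to compound 4 (0.47 log units; beyond the scatter). The expected value for compound 4 is 30 nM in this assay, between 10 nM and 90 nM.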

Compound 4, half-maximal inhibitory concentration: 105 nM
Beside the measured number, compound 4's estimate is 3.5-fold (0.54 log units) below it; the whole stated range lies below it.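

In this assay, among the compounds shown here, swapping the amine for the hydroxyl on a six-membered ring costs more than the earlier steps indicated: an at least 10-fold higher number from compound 3 to compound 4 (1.02 log units; beyond the scatter), and likewise an at least 7.0-fold higher number from compound 2 to compound 4 (0.84 log units; beyond the scatter), with each of these steps starting from a limit of the assay rather than a number. Among the hydroxyl compounds, which both give true numbers, the group is not indifferent to its ring either: a 3.3-fold higher number from compound 1 to compound 4 (0.52 log units; beyond the scatter).

The compounds shown change the group and its place on the ring together, so it stays open which of the two carries the loss. A 4-hydroxypiperidin-1-yl or a 3-aminopiperidin-1-yl group would separate them.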